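The source may report more compounds than this note shows. Statements on the series, on what has been measured and on what is new or still open speak of the compounds shown alone.

Compound 3 `O=C(CN1CCCC1)Nc1ccc(-c2nc3ccccc3[nH]2)cc1` is one of the compounds in this study with a number, rather than a limit, in an ADME assay on MT4 cells (Homo sapiens) for cytotoxicity, read by MTT assay, with a stated time of 96 h (on this read-out lower numbers stand for higher toxicity in this test and higher numbers for lower toxicity in this test), where compound 3 gives 40000 nM. Compound 1 `CN1CCN(CC(=O)Nc2ccc(-c3nc4cc(C(F)(F)F)ccc4n3C)cc2)CC1` gives 22000 nM in this assay, and the two values lie within the scatter of each other, so neither can be set apart from the other. Compound 2 `CCC(=O)Nc1ccc(-c2nc3cc(C(F)(F)F)ccc3[nH]2)cc1`, which carries a propanoyl group on the amide nitrogen, reaches only (the limit of >= 100000 nM in this assay, at which 1 of the 3 values shown sits), and its entry in this assay of >= 100000 nM is therefore a limit and not a number.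

Compound 4 `CCC(=O)Nc1ccc(-c2nc3ccccc3[nH]2)cc1` has not yet been measured. It differs from compound 3 in one place: methyl in place of pyrrolidin-1-yl on a saturated chain carbon bound to a carbonyl carbon. Among the measured compounds shown here, no measured pair in this study shows this exact change, so its size can only be expected, not read off. Given that compound 2, which bears the same propanoyl group, sits at a limit in this assay, the change from compound 3 to compound 4 is expected to move the number upward by a 2.1-fold higher number from compound 3 to compound 4 (0.33 log units; beyond the scatter), a step of modest size that may not clear the scatter. Compound 4 is accordingly estimated at 85000 nM in this assay, within a range from 35000 nM to 200000 nM, with a fair chance that only a limit is reported.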

Compound 4, half-maximal cytotoxic concentration: 35000 nM
For compound 4 the middle estimate is 2.4-fold (0.39 log units) above the measured one; measured number inside the range.
By their numbers in this assay, from the lowest: compounds 1, 4 and 3 (each within the scatter of the next). At a limit, above all of these: compound 2.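

In this assay, methyl in place of pyrrolidin-1-yl on a saturated chain carbon bound to a carbonyl carbon gives a 1.1-fold lower number from compound 3 to compound 4 (0.06 log units; within the scatter), so at this place the read-out does not separate the ring-bearing chain from the plain propanoyl group. The propanoyl group alone therefore does not carry a compound to the top of the values shown: the step that reaches beyond the scatter is the one with hydrogen in place of trifluoromethyl on an aromatic carbon, an at least 2.8-fold lower number from compound 2 to compound 4 (0.45 log units; beyond the scatter). Compound 2 gives a limit and not a number, so the full size of that step stays unknown: the limit of >= 100000 nM in this assay, at which 1 of the 4 values shown sits.

What the compounds shown leave open is whether the exchange at the chain carbon reads the same when trifluoromethyl sits on the core, as only the unsubstituted core offers this pair. They also leave open how a primary amine, a carboxylic acid or a longer chain at this place would read in this assay, and whether any such group would move the number beyond the scatter.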